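Rearranged trimethoxyphenyl: from compound 3 to compound 4

The source may report more compounds than this note shows. Statements on the series, on what has been measured and on what is new or still open speak of the compounds shown alone.

Measured in a functional assay on SW-620 cells (Homo sapiens) for cytotoxicity, read by MTT assay, with stated times of 4 h and 72 h, tested at 1 uM; a lower number here means a stronger inhibitor, a higher number a weaker inhibitor:
- compound 1 `Cc1cc(Nc2ccc(C(=O)/C=C/c3cccc(Br)n3)cc2)n2nc(SCc3nc4ccccc4[nH]3)nc2n1` gives 58 nM
- compound 2 `Cc1cc(Nc2ccc(C(=O)/C=C/c3ccc(Br)cn3)cc2)n2nc(SCc3nc4ccccc4[nH]3)nc2n1` gives 110 nM
- compound 3 `COc1cc(/C=C/C(=O)c2ccc(Nc3cc(C)nc4nc(SCc5nc6ccccc6[nH]5)nn34)cc2)cc(OC)c1OC` gives 75 nM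

Compound 3 at 75 nM lies within the scatter of the other two values, as a 1.3-fold higher number from compound 1 to compound 3 (0.11 log units; within the scatter) and a 1.5-fold lower number from compound 2 to compound 3 (0.17 log units; within the scatter) show. The remaining comparison, a 1.9-fold higher number from compound 1 to compound 2 (0.28 log units; within the scatter) again, also stays within the scatter.

Compound 4 `COc1cc(OC)c(/C=C/C(=O)c2ccc(Nc3cc(C)nc4nc(SCc5nc6ccccc6[nH]5)nn34)cc2)c(OC)c1` has not yet been measured. Its difference from compound 3 is 2,4,6-trimethoxyphenyl in place of 3,4,5-trimethoxyphenyl on a double-bonded chain carbon bound to a double-bonded chain carbon and it keeps the same atoms, joined differently. Among the measured compounds shown here, no measured pair isolates a rearrangement of the methoxy groups, so the evidence is indirect. Replacing the whole group at this place in compound 1 gave only a 1.3-fold higher number from compound 1 to compound 3 (0.11 log units; within the scatter) and the same replacement in compound 2 gave only a 1.5-fold lower number from compound 2 to compound 3 (0.17 log units; within the scatter) in these data. No step beyond the scatter is therefore expected, and the expected step is a 1.2-fold higher number from compound 3 to compound 4 (0.08 log units; within the scatter) in either direction of little meaning. In this assay compound 4 is estimated at 90 nM with an expected range of 35 nM to 250 nM around that figure.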

Compound 4, half-maximal inhibitory concentration: 260 nM
Estimate against measurement, compound 4: 2.9-fold (0.46 log units) below; measured number above the stated range.
By their numbers in this assay, from the lowest: compounds 1, 3 and 2 (each within the scatter of the next); then compound 4.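

In this assay, the place on a double-bonded chain carbon bound to a double-bonded chain carbon had shown no step beyond the scatter among the earlier groups, yet rearranging the methoxy groups, with the atoms unchanged, gives a 3.5-fold higher number from compound 3 to compound 4 (0.54 log units; beyond the scatter). The 2,4,6-trimethoxyphenyl group also separates compound 4 from both bromopyridinyl compounds, with a 2.4-fold higher number from compound 2 to compound 4 (0.37 log units; beyond the scatter) and a 4.5-fold higher number from compound 1 to compound 4 (0.65 log units; beyond the scatter), so this place is sensitive to how the methoxy groups are arranged on the phenyl ring. No measurement bears on why the rearrangement has this result.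

The compounds shown leave open whether all three methoxy groups of the 2,4,6-trimethoxyphenyl group contribute to the step or only some of them. They also leave open what a phenyl ring carrying a single methoxy group or an amine would give at this place.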